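Swapping a ring oxygen for a ring sulfoxide on the urea

The source may report more compounds than this note shows. Statements on the series, on what has been measured and on what is new or still open speak of the compounds shown alone.

Measured so far:
- compound 1, `O=C(NC1CC[S+]([O-])CC1)N1CCC(c2nc(-c3ccc4ccccc4n3)no2)CC1`: 850 nM
- compound 2, `Cc1noc(C)c1NC(=O)N1CCC(c2nc(-c3ccc4ccccc4n3)no2)CC1`: 3000 nM
- compound 3, `O=C(Nc1ccccc1Cl)N1CCC(c2nc(-c3ccc4ccccc4n3)no2)CC1`: 510 nM

All three share the same core and differ only in the group carried on the urea nitrogen. They were tested in a functional assay on Shh Light II cells (Mus musculus) for inhibition, read by a luciferase reporter; on this read-out higher numbers stand for weaker inhibition and lower numbers for stronger inhibition. On the numbers shown, compound 1 stands second highest of the three: compound 3 sits nearest, with a 1.7-fold lower number from compound 1 to compound 3 (0.22 log units; within the scatter), and compound 2 furthest, with a 3.5-fold higher number from compound 1 to compound 2 (0.55 log units; beyond the scatter).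

Compound 4, `O=C(NC1CCOCC1)N1CCC(c2nc(-c3ccc4ccccc4n3)no2)CC1`, takes the step from compound 1 in which (a group of 6 heavy atoms (5 carbon, 1 oxygen; one six-membered non-aromatic ring with 1 hetero atom) in place of a group of 7 heavy atoms (5 carbon, 1 oxygen, 1 sulfur; one six-membered non-aromatic ring with 1 hetero atom), on an amide-type nitrogen). The two ring systems are alike in size and shape; the change removes the sulfur and its attached oxygen and puts a ring oxygen in their place.

Going by the values given here, no measured step matches this change directly. The nearest guides are the step to compound 3, which is within the scatter, and the step to compound 2, which is modest but involves a quite different aromatic group. A change this small is therefore expected to move the number little, if at all, beyond the scatter. Compound 4 is expected to come in at 900 nM, with a range of 400 nM to 2000 nM, meaning an expected step of a 1.1-fold higher number from compound 1 to compound 4 (0.02 log units; within the scatter).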

Compound 4, half-maximal inhibitory concentration: 480 nM
Compound 4: the middle estimate sits 1.9-fold (0.27 log units) above what was measured; the range from low to high includes it.
By their numbers in this assay, from the lowest: compounds 4, 3 and 1 (each within the scatter of the next); then compound 2.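

In this assay, oxan-4-yl on the amide-type nitrogen cannot be told apart from the sulfur-bearing ring of compound 1 (a 1.8-fold lower number from compound 1 to compound 4 (0.25 log units; within the scatter)), so replacing the sulfur and its attached oxygen with a ring oxygen leaves the number within the scatter. Oxan-4-yl also matches the aromatic 2-chlorophenyl (a 1.1-fold lower number from compound 3 to compound 4 (0.03 log units; within the scatter)), which shows that non-aromatic and aromatic six-membered rings can both sit at this place, whereas compound 2, with 3,5-dimethyl-1,2-oxazol-4-yl, stands apart (a 6.3-fold lower number from compound 2 to compound 4 (0.80 log units; beyond the scatter)). Nothing available explains the separation of compound 2 from the other three.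

Still open, on these data alone, is whether cyclohexyl, a ring of carbon only, would fall with compound 4. It is also unknown how an amine or a carboxylic acid on the oxan-4-yl ring would shift the number.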